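Chalcone-pyrazole series: aryl swap on the carbonyl carbon

The source may report more compounds than this note shows. Statements on the series, on what has been measured and on what is new or still open speak of the compounds shown alone.

Three compounds have numbers in a functional assay on HOP-62 cells (Homo sapiens) for inhibition, read by sulforhodamine B assay, with a stated time of 48 h; on this read-out lower numbers stand for higher toxicity in this test and higher numbers for lower toxicity in this test. Compound 1 `COc1ccc(-c2cc(/C=C/C(=O)c3ccc(OC)c(OC)c3)[nH]n2)cc1` gives 35300 nM, compound 2 `COc1cc(-c2cc(/C=C/C(=O)c3ccc(Cl)c(Cl)c3)[nH]n2)cc(OC)c1OC` gives 42600 nM, and compound 3 `COc1ccc(-c2cc(/C=C/C(=O)c3cc(OC)c(OC)c(OC)c3)[nH]n2)cc1OC` gives 8850 nM. Compound 2 stands at the highest of the three numbers; its nearest neighbour is compound 1, within the scatter, while compound 3 sits furthest away, beyond the scatter. Compound 4 `COc1ccc(C(=O)/C=C/c2cc(-c3cc(OC)c(OC)c(OC)c3)n[nH]2)cc1OC` is not yet measured. Its difference from compound 2 is 3,4-dimethoxyphenyl in place of 3,4-dichlorophenyl on a carbonyl carbon. Among the compounds with values here, no measured pair differs in one place only, so no step is available. Given compound 3 with 8850 nM carrying methoxy-bearing aryl groups at both ends, a modest move toward lower numbers is expected for compound 4, of roughly a 2.4-fold lower number from compound 2 to compound 4 (0.37 log units; beyond the scatter). Compound 4 is estimated at 18000 nM, in the range 7000 nM to 45000 nM.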

Compound 4, concentration lethal to 50% of the cells: 5350 nM
Compound 4: middle estimate off by 3.4-fold (0.53 log units), on the high side, and the stated range ends above it.
By their numbers in this assay, from the lowest: compounds 4 and 3 (each within the scatter of the next); then compounds 1 and 2 (each within the scatter of the next).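

In this assay, within the data shown here, the group on the carbonyl carbon proves to matter: with the rest of the molecule unchanged, 3,4-dimethoxyphenyl in place of 3,4-dichlorophenyl gives an 8.0-fold lower number from compound 2 to compound 4 (0.90 log units; beyond the scatter) and is the only single-place comparison so far. Nothing at hand explains the size of this step. From the compounds shown here alone, whether it follows from losing the chlorines or gaining the methoxy groups stays open, since both change together. Also open, going by these compounds, is how an aryl group carrying a single methoxy, a fluorine or an amine would read at this position.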